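The source may report more compounds than this note shows. Statements on the series, on what has been measured and on what is new or still open speak of the compounds shown alone.

Within the data shown here, in a functional assay (Saphenous vein) with Canis familiaris (Canis lupus familiaris) as the target (on this read-out higher numbers stand for higher potency (the scale is a negative logarithm) and lower numbers for lower potency), compound 1 `COc1ccc(C(=O)Nc2ccc(-c3ccncc3)cc2)cc1CCCN(C)C` gives 7.8, and compound 2 `CCOc1ccc(NC(=O)c2ccc(OC)c(CCCN(C)C)c2)cc1` gives 6.9, the lower of the two numbers measured so far. Compound 3 `COc1ccc(C(=O)Nc2ccc(-c3ccc(C=O)cc3C)cc2)cc1CCCN(C)C` has not yet been measured. Its difference from compound 2 is 4-formyl-2-methylphenyl in place of ethoxy on an aromatic carbon, para to a large group.

Among the measured compounds shown here, one measured step bears on this change: a number 0.90 log units lower from compound 1 to compound 2 (beyond the scatter), with ethoxy in place of pyridin-4-yl on an aromatic carbon. For the measured compounds named here, this single step is the only guide, and no measured compound carries the formyl or methyl group of the entering substituent. Like compound 1, at 7.8, compound 3 has an aromatic ring where compound 2 has ethoxy, so a number nearer to that of compound 1 is expected in this assay, though the ring itself differs. The expected change is a number 1.00 log units higher from compound 2 to compound 3 (beyond the scatter), a rise of about the same size as the measured step. The estimate for compound 3 is 7.9, with an expected range from 7.2 to 8.6.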

Compound 3, negative logarithm of the antagonist equilibrium constant: 8.4
Compound 3: the middle estimate sits 0.50 log units below what was measured, within the range that was stated.
By their numbers in this assay, from the lowest: compound 2; then compound 1; then compound 3.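

In this assay, putting 4-formyl-2-methylphenyl in place of ethoxy on this aromatic carbon, para to a large group, gives a number 1.50 log units higher from compound 2 to compound 3 (beyond the scatter), which shows that the higher number of compound 1 does not depend on the nitrogen of a pyridin-4-yl ring: a six-membered aromatic ring of carbon only, bearing formyl and methyl groups, also stands well above the ethoxy compound. Exchanging one ring for the other gives a number 0.60 log units higher from compound 1 to compound 3 (beyond the scatter), so the presence of an aromatic ring at this position does not alone fix the number, and the identity of the ring and what it carries also matter. Nothing among the available data explains either step.

Since the pyridin-4-yl and 4-formyl-2-methylphenyl groups differ in several features at once, the compounds shown cannot divide the gain among the ring atoms, the formyl group and the methyl group. Going by these compounds, it remains open whether plain phenyl or 2-methylphenyl would hold the number of compound 3, and whether a carboxylic acid, a nitrile or an amine could stand in place of the formyl group.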